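A few compounds are considered here, and "the series" means these few. Any claim that something is new, unique, unknown or untested is made for them only; others in the source may bear on it.

Measured so far in the series:

Compound 1, `Nc1ccc2nc(N)sc2c1`. In a functional assay on the whole organism with Rattus norvegicus as the target (a higher number here means that more compound is needed for the effect, a lower number that less compound is needed), compound 1 gives > 10 mg/kg, which is a limit of the assay and not a number.
Compound 2, `CCC(C)(C)c1ccc2nc(N)sc2c1`. In this assay compound 2 gives > 10 mg/kg, again a limit rather than a number.
Compound 3, `CCn1c(=N)sc2cc(OC(F)(F)F)ccc21`. In this assay compound 3 gives 5 mg/kg.

Among the compounds with values here, compound 3 therefore stands as the only real number in this assay; the other two values sit at the limit of > 10 mg/kg in this assay, at which 2 of the 3 values shown sit. Within the data shown here, the one step between measured compounds that differ in a single place, a step that the two limits leave unreadable from compound 1 to compound 2, has both ends at a limit and cannot be read; it also concerns a different part of the structure.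

The next compound, compound 4, is `N=c1sc2cc(OC(F)(F)F)ccc2n1CCS(=O)(=O)O`. It differs from compound 3 as follows: sulfo in place of hydrogen on a saturated chain carbon, two bonds along the chain from an aromatic nitrogen. Among the measured compounds shown here, no measured step touches this kind of change, so nothing so far gives a direction or a size for it. With no guidance, the working expectation for compound 4 in this assay is a value close to that of compound 3, with a wide range allowed for the untested change: compound 4 is estimated at 6 mg/kg, between 2 mg/kg and 20 mg/kg. The step this estimate implies, a 1.2-fold higher number from compound 3 to compound 4 (0.08 log units; within the scatter), is expected to lie within the usual scatter.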

Compound 4, dose for half-maximal effect: > 10 mg/kg
Compound 4 gave a limit, no number; the forecaster's own chance of this, stated with the estimate: 40%; at least 1.6-fold (0.22 log units) between middle value and limit.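

The change from ethyl to 2-sulfoethyl, on a saturated chain carbon two bonds along the chain from an aromatic nitrogen, gives the series its first reading at this position: in this assay the result is an at least 2.0-fold higher number from compound 3 to compound 4 (0.30 log units; that floor lies within the scatter). Within the data shown here, only this floor can be read, so the true size of the step is unknown, and compound 3 remains the only compound with a real number. The value of compound 4, > 10 mg/kg, is a limit of the assay and not a number, and it places compound 4 with compounds 1 and 2, whose steps cannot be read: the limit of > 10 mg/kg in this assay, at which 3 of the 4 values shown sit.

Still open, going by these compounds, is whether the outcome belongs to the sulfo group itself or to any added group at this place, which a carboxylic acid, an amine or a hydroxyl on the same chain carbon, or a plain longer chain such as propyl, would help to separate. Also open, on these data alone, is how far past its limit the number of compound 4 lies, and whether sulfo at this place would read the same way on a core carrying a different group from that of compound 3.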